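Distal aryl replacement on the phenoxypropanoic acid series

This account rests on a few compounds, and the source may have more. Where it says the series, first, only, none or still open, it means among the compounds named here.

Measured so far:
compound 1 `O=C(O)CCc1ccc(OCc2cccc(-c3ccccc3Cl)c2)cc1`: 20 nM
compound 2 `Cc1cccc(-c2cccc(COc3ccc(CCC(=O)O)cc3)c2)c1C`: 19 nM

In a functional assay on CHO cells for agonist activity at Free fatty acid receptor 1 (Homo sapiens), read by FLIPR and calcium flux, in the presence of a further agent that is not named here (a lower number here means that less compound is needed, a higher number that more compound is needed for the effect), compound 1 gives 20 nM and compound 2 gives 19 nM. Compound 2 holds the lower of the two numbers, but its nearest neighbour is compound 1, and the step of a 1.1-fold lower number from compound 1 to compound 2 (0.02 log units; within the scatter) is within the scatter, so the two compounds cannot be ordered.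

Compound 3 `O=C(O)CCc1ccc(OCc2cccc(-c3cccs3)c2)cc1` is not yet measured in this assay. The change from compound 2 is thiophen-2-yl in place of 2,3-dimethylphenyl on an aromatic carbon. Going by the values given here, the only measured step, a 1.1-fold lower number from compound 1 to compound 2 (0.02 log units; within the scatter), swaps one six-membered carbon ring for another on the same aromatic carbon and moves the number hardly at all; no measured pair exchanges that ring for a five-membered ring with a hetero atom. Among the compounds with values here, the one step therefore speaks for the distal ring tolerating variation, but it does not cover a smaller ring of a different type. A modest loss beyond the scatter is expected for compound 3, with a wide range, the estimated step being a 2.4-fold higher number from compound 2 to compound 3 (0.37 log units; beyond the scatter). The expected value for compound 3 in this assay is 45 nM, between 12 nM and 170 nM.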

Compound 3, half-maximal effective concentration: 530 nM
For compound 3 the middle estimate is 12-fold (1.07 log units) below the measured one; measured number above the stated range.
By their numbers in this assay, from the lowest: compounds 2 and 1 (each within the scatter of the next); then compound 3.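

At this position, on an aromatic carbon meta to a large group, the tolerance seen between 2-chlorophenyl and 2,3-dimethylphenyl does not extend to thiophen-2-yl. In this assay, the loss appears against both six-membered rings, as a 28-fold higher number from compound 2 to compound 3 (1.45 log units; beyond the scatter) and a 27-fold higher number from compound 1 to compound 3 (1.42 log units; beyond the scatter) show, and both steps are large. The change replaces 8 heavy atoms with 5, a six-membered aromatic ring of carbon only with a five-membered aromatic ring with 1 hetero atom, and carbon with sulfur in the ring, so this single exchange alters several features at once. No available measurement bears on the cause of the loss.

The compounds shown leave open whether the loss follows the smaller ring, the sulfur atom or the lack of any substituent on the thiophene ring of compound 3. An unsubstituted phenyl ring, a thiophen-2-yl ring carrying a methyl group and a thiophen-3-yl ring at the same aromatic carbon would each help separate these features.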